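Amide to urea with a chloro-bearing ring: what to expect

The source may hold more compounds than are shown below. What is called first, only, known or untested is meant among the compounds shown, and "the series" means these compounds.

Measured compounds:
- compound 1, `COc1cc(-c2nn(-c3cccc(NC(=O)c4ccc(Cl)c(C(F)(F)F)c4)c3)cc2-c2ccncc2)ccc1Cl`: 4130 nM
- compound 2, `COc1cc(-c2nn(-c3cccc(NC(=O)c4cccc(C(F)(F)F)c4)c3)cc2-c2ccncc2)ccc1Cl`: 895 nM
- compound 3, `O=C(Nc1cccc(-n2cc(-c3ccncc3)c(-c3ccc(Cl)c(O)c3)n2)c1)Nc1cc(C(F)(F)F)cc(C(F)(F)F)c1`: 765 nM

In a functional assay on SF-539 cells (Homo sapiens) for inhibition, read by sulforhodamine B assay, with a stated time of 48 h (on this read-out lower numbers stand for stronger inhibition of growth and higher numbers for weaker inhibition of growth), compound 2 gives 895 nM, the second highest of the three numbers. Compound 3 sits nearest, within the scatter of compound 2, so nothing separates the two. For the measured compounds named here, compound 1 stands furthest away, and the single step that connects them, a 4.6-fold lower number from compound 1 to compound 2 (0.66 log units; beyond the scatter), is a modest but real change that comes with hydrogen in place of chloro on an aromatic carbon.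

Compound 4, `COc1cc(-c2nn(-c3cccc(NC(=O)Nc4ccc(Cl)c(C(F)(F)F)c4)c3)cc2-c2ccncc2)ccc1Cl`, has not yet been measured. It differs from compound 2 by (4-chloro-3-(trifluoromethyl)phenyl)amino in place of 3-(trifluoromethyl)phenyl on a carbonyl carbon. Going by the values given here, this change does two things at once: it brings back the chloro that compound 1 carries, and it turns the amide into a urea, as compound 3 has, though compound 3 also differs from compound 2 elsewhere and no measured step isolates the urea alone.

Among the compounds with values here, the one step that bears on the change, a 4.6-fold lower number from compound 1 to compound 2 (0.66 log units; beyond the scatter), ran the opposite way to the chloro that now enters, so a rise of similar size seems the most likely outcome for compound 4 in this assay, with the urea an unknown on top. Compound 4 is therefore expected at about 2500 nM, in the range 600 nM to 9000 nM, a step of a 2.8-fold higher number from compound 2 to compound 4 (0.45 log units; beyond the scatter).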

Compound 4, concentration for 50% growth inhibition: 1650 nM
Estimate against measurement, compound 4: 1.5-fold (0.18 log units) above; measured number inside the range.
By their numbers in this assay, from the lowest: compounds 3, 2 and 4 (each within the scatter of the next, the first and the last beyond it); then compound 1.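

The change from amide to urea can now be read on its own, with the chloro kept in place: in this assay the added amino nitrogen on the carbonyl carbon gives a 2.5-fold lower number from compound 1 to compound 4 (0.40 log units; beyond the scatter) and lies beyond the scatter. The earlier compounds shown here showed only that adding the chloro to an amide goes with weaker growth inhibition, whereas the urea that carries this chloro gives a 1.8-fold higher number from compound 2 to compound 4 (0.27 log units; within the scatter) and lies within the scatter, so it cannot be told apart from the amide without the chloro. This position therefore responds to the atoms that join the ring to the carbonyl carbon as well as to the groups on the ring, although this rests on a single pair of compounds.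

Nothing shown here explains why the added nitrogen has this effect. Also open, as far as these compounds go, is whether a urea without the chloro would differ from compound 2, and whether a methylene group or an oxygen atom in place of the amino nitrogen would give the same result.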